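This account rests on a few compounds, and the source may have more. Where it says the series, first, only, none or still open, it means among the compounds named here.

Compound 1 `O=c1ccoc2cc(OCc3cn(Cc4ccc(Cl)cc4)nn3)ccc12` gives in a functional assay on A549 cells (Homo sapiens) for cytotoxicity, read by MTT assay, with a stated time of 48 h (a higher number here means a weaker inhibitor, a lower number a stronger inhibitor), only > 100000 nM, which is a limit of the assay rather than a number. Within the data shown here, compound 2 `O=c1ccoc2cc(OCc3cn(Cc4cccc([N+](=O)[O-])c4)nn3)ccc12` in this assay gives 9450 nM, the only actual number in the set so far. The remaining value, that of compound 1, is a limit (the limit of > 100000 nM in this assay, at which 1 of the 2 values shown sits). Among the measured compounds shown here, the step of an at least 10-fold lower number from compound 1 to compound 2 (1.02 log units; beyond the scatter) is the sole measured step, and it changes the substituent and the nitro pattern together. Compound 3 `O=c1ccoc2cc(OCc3cn(Cc4ccc([N+](=O)[O-])cc4)nn3)ccc12` differs from compound 2 by 4-nitrophenyl in place of 3-nitrophenyl on a saturated chain carbon bound to an aromatic nitrogen. For the measured compounds named here, no measured step isolates a change from 3-nitrophenyl to 4-nitrophenyl alone, so the one step at hand offers no direct guide to this change, and the same atoms are kept, joined differently. For compound 3 the expected step is a 1.1-fold lower number from compound 2 to compound 3 (0.02 log units; within the scatter), not beyond the scatter. Compound 3 is estimated at 9000 nM, with a range from 3000 nM to 30000 nM.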

Compound 3, half-maximal inhibitory concentration: > 100000 nM
Compound 3 ended at the assay's limit; the forecaster's own chance of this, stated with the estimate: 10%; middle value at least 11-fold (1.04 log units) from the limit.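

The step of an at least 10-fold higher number from compound 2 to compound 3 (1.02 log units; beyond the scatter) in this assay shows that this place is sensitive to the arrangement of the group, not only to its atoms: 4-nitrophenyl and 3-nitrophenyl have the same atom counts, yet the change alone is large. A nitro group as such therefore does not go with a measurable value in this set, since compound 3 carries one and compound 2 alone gives an actual number. The step between compound 1 and compound 3 cannot be read, and both values are limits of the assay: the limit of > 100000 nM in this assay, at which 2 of the 3 values shown sit.

As far as these compounds go, it remains open whether the value of compound 2 depends on the nitro group itself or would persist with a nitrile or an amine on the same phenyl carbon. Also open, from the compounds shown here alone, is how a longer chain in place of the saturated chain carbon bound to the aromatic nitrogen would behave.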